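This account rests on a few compounds, and the source may have more. Where it says the series, first, only, none or still open, it means among the compounds named here.

In a functional assay on HCT-116 cells (Homo sapiens) for antiproliferative activity, read by CellTiter-Glo, with a stated time of 72 h (a lower number here means a stronger inhibitor, a higher number a weaker inhibitor), compound 3 `O=C(NO)c1ccc(/C=C/c2ccncc2)cc1`, which has only hydrogen on the ring carbon that matters here, gives 3910 nM. Within the data shown here, of the two true numbers so far, this is the higher, and compound 1 `Cc1ccc(-c2cc(/C=C/c3ccc(C(=O)NO)cc3)ccn2)c(F)c1` gives 800 nM. Compound 2 `O=C(NO)c1ccc(/C=C/c2ccnc(Br)c2)cc1` reads > 10000 nM, which is a limit of the assay and not a number.

Compound 4 `O=C(NO)c1ccc(/C=C/c2ccnc(-c3ccsc3)c2)cc1` is made from compound 3 by a single change: thiophen-3-yl in place of hydrogen on an aromatic carbon. The new thiophen-3-yl group sits on an aromatic carbon next to the ring nitrogen.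

Two kinds of measured step bear on this. Compound 1 carries an aromatic ring, 2-fluoro-4-methylphenyl, at that same carbon, and removing it gives a 4.9-fold higher number from compound 1 to compound 3 (0.69 log units; beyond the scatter). Bromo at that carbon does not bring the number down, as an at least 2.5-fold lower number from compound 2 to compound 3 (0.40 log units; beyond the scatter) shows, and an at least 12-fold higher number from compound 1 to compound 2 (1.09 log units; beyond the scatter) separates it from the aromatic ring. This rests on a single ring example, and thiophen-3-yl is a different ring, so the gain may not carry over in full. Among the measured compounds shown here, a modest drop in this assay is therefore expected, perhaps somewhat smaller than the one seen with compound 1. The expected step is a 3.9-fold lower number from compound 3 to compound 4 (0.59 log units; beyond the scatter). For compound 4 the estimated value is 1000 nM, with an expected range of 350 nM to 3000 nM.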

Compound 4, half-maximal inhibitory concentration: 1910 nM
Compound 4: the middle estimate sits 1.9-fold (0.28 log units) below what was measured; low and high end bracket the measured number.
By their numbers in this assay, from the lowest: compound 1; then compound 4; then compound 3. At a limit, above all of these: compound 2.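

In this assay, thiophen-3-yl on this aromatic carbon next to the ring nitrogen also lowers the number, with a 2.0-fold lower number from compound 3 to compound 4 (0.31 log units; beyond the scatter), so among the compounds shown the gain from a ring at this carbon is not limited to the 2-fluoro-4-methylphenyl of compound 1. The size of the gain does depend on the ring, however: a 2.4-fold higher number from compound 1 to compound 4 (0.38 log units; beyond the scatter), so the two ring-bearing compounds are not interchangeable here. Compound 2, with bromo at this carbon, reads as a limit and not a number, which makes an at least 5.2-fold lower number from compound 2 to compound 4 (0.71 log units; beyond the scatter) a bound rather than an exact measure of how far thiophen-3-yl stands from bromo: the limit of > 10000 nM in this assay, at which 1 of the 4 values shown sits.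

On these data alone, it remains open whether the gain needs an aromatic ring at all, and an amine, a morpholine ring or a short alkyl chain at this carbon would test that. Also open, as far as these compounds go, is what gives 2-fluoro-4-methylphenyl its lead over thiophen-3-yl, and a plain phenyl ring would help separate the effect of the six-membered ring from that of its fluoro and methyl groups.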